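Swapping ethyl for trifluoromethyl on a cytotoxicity series

The source may report more compounds than this note shows. Statements on the series, on what has been measured and on what is new or still open speak of the compounds shown alone.

Of the compounds shown here, three have been measured in a functional assay on A549 cells (Homo sapiens) for cytotoxicity, read by MTT assay, with a stated time of 72 h; on this read-out higher numbers stand for weaker inhibition and lower numbers for stronger inhibition. Compound 1 `O=C(Nc1ccc(Oc2ccnc3[nH]ccc23)cc1)c1cc(-c2ccc(C(F)(F)F)cc2)ccn1` gives 3950 nM. Compound 2 `Cc1cccc(-c2ccnc(C(=O)Nc3ccc(Oc4ccnc5[nH]ccc45)c(F)c3)c2)c1` gives 1750 nM. Compound 3 `CCc1ccc(-c2ccnc(C(=O)Nc3ccc(Oc4ccnc5[nH]ccc45)c(F)c3)c2)cc1` gives 3370 nM, which puts it second highest of the three, close to compound 1 and furthest from compound 2, though all three lie within the scatter of one another. Among the compounds with values here, the only single-point step recorded, a 1.9-fold higher number from compound 2 to compound 3 (0.28 log units; within the scatter), changed nothing beyond the scatter.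

Compound 4 `O=C(Nc1ccc(Oc2ccnc3[nH]ccc23)c(F)c1)c1cc(-c2ccc(C(F)(F)F)cc2)ccn1` differs from compound 3 by trifluoromethyl in place of ethyl on an aromatic carbon. Within the data shown here, no measured step covers this exact change, but compound 1 carries the same trifluoromethylphenyl group on a core that lacks the fluorine of compounds 2, 3 and 4, and its value sits within the scatter of compound 3. Among the measured compounds shown here, with the one recorded step also flat, the expectation for compound 4 is a change of a 1.1-fold higher number from compound 3 to compound 4 (0.04 log units; within the scatter), that is, no shift beyond the scatter in this assay. Compound 4 is therefore estimated at 3700 nM, with a range from 1700 nM to 8000 nM.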

Compound 4, half-maximal inhibitory concentration: 4920 nM
Compound 4: middle estimate off by 1.3-fold (0.12 log units), on the low side, and the stated range covers the measured number.
By their numbers in this assay, from the lowest: compounds 2, 3, 1 and 4 (each within the scatter of the next, the first and the last beyond it).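

In this assay, trifluoromethyl in place of ethyl on this aromatic carbon leaves the result within the scatter (a 1.5-fold higher number from compound 3 to compound 4 (0.16 log units; within the scatter)), so this exchange of two quite different groups has no clear effect here. Fluoro in place of hydrogen on the shared core is also within the scatter (a 1.2-fold higher number from compound 1 to compound 4 (0.10 log units; within the scatter)), whereas 4-(trifluoromethyl)phenyl in place of 3-methylphenyl gives the first step in this set beyond the scatter, though only a modest one (a 2.8-fold higher number from compound 2 to compound 4 (0.45 log units; beyond the scatter)). No measurement shown here explains any of these steps.

The compounds shown leave open whether an amine, a carboxylic acid or a longer chain at this same place would move the number further. They also leave open whether these small steps would hold in any other test.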